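The source may hold more compounds than are shown below. What is called first, only, known or untested is meant among the compounds shown, and "the series" means these compounds.

Measured so far in a functional assay on Jurkat cells (Homo sapiens) for inhibition; on this read-out higher numbers stand for weaker inhibition and lower numbers for stronger inhibition:
Compound 1 `CC(C)[C@H](NC(=O)COc1cccc2ccccc12)C(=O)N[C@@H](CC(=O)O)C(=O)CSc1nnc(-c2ccccc2)o1` gives 150000 nM.
Compound 2 `CC(C)[C@H](NC(=O)COc1cccc2ccccc12)C(=O)N[C@@H](CC(=O)O)C(=O)CSc1nc[nH]n1` gives > 200000 nM, which is a limit of the assay and not a number.
Compound 3 `Cc1cc(OCC(=O)[C@H](CC(=O)O)NC(=O)[C@@H](NC(=O)COc2cccc3ccccc23)C(C)C)nc(C)n1` gives > 200000 nM, again a limit of the assay.

Compound 2 therefore stands at the edge of what this assay can report, with only a limit known for it; that limit is the limit of > 200000 nM in this assay, at which 2 of the 3 values shown sit. Compound 4 `CC(C)[C@H](NC(=O)COc1cccc2ccccc12)C(=O)N[C@@H](CC(=O)O)C(=O)COc1nncc(Cl)c1Cl` differs from compound 2 by (4,5-dichloropyridazin-3-yl)oxy in place of (1H-1,2,4-triazol-3-yl)sulfanyl on a saturated chain carbon bound to a carbonyl carbon. For the measured compounds named here, only one measured step starts at compound 2: a step that the two limits leave unreadable from compound 2 to compound 3, a change of the same kind at the same place, which ends at a limit too. The remaining steps, an at least 1.3-fold higher number from compound 1 to compound 2 (0.12 log units; that floor lies within the scatter) and an at least 1.3-fold higher number from compound 1 to compound 3 (0.12 log units; that floor lies within the scatter), show that neither variation of this group produced a readable number below the limit. Going by the values given here, no step here gives a direction beyond the scatter, so compound 4 is expected to stay near the limit, with a step of a number no higher from compound 2 to compound 4 (the limit leaves the size open). In this assay compound 4 is estimated at 200000 nM, within 80000 nM to 500000 nM, and a limit rather than a number is expected to remain the more likely outcome.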

Compound 4, half-maximal inhibitory concentration: > 200000 nM
Compound 4: only a limit was reported; the forecaster's own chance of this, stated with the estimate: 70%; the middle value sits exactly at the limit.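

In this assay compound 4 gives > 200000 nM, which is a limit of the assay and not a number. So a six-membered aromatic ring with two chlorines, as (4,5-dichloropyridazin-3-yl)oxy, on the saturated chain carbon bound to a carbonyl carbon also yields no readable number, and the steps from compound 2 and from compound 3 to compound 4 cannot be read. For the compounds shown here, the only step with a floor, an at least 1.3-fold higher number from compound 1 to compound 4 (0.12 log units; that floor lies within the scatter), gives no direction, and the limit now holds most of the series: the limit of > 200000 nM in this assay, at which 3 of the 4 values shown sit.

As far as these compounds go, it remains open whether any group at this place can give a number clearly lower than that of compound 1, which gives 150000 nM. A 2,3,5,6-tetrafluorophenoxy group at this place would be one further test of that question.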